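The source may hold more compounds than are shown below. What is called first, only, known or untested is meant among the compounds shown, and "the series" means these compounds.

In an ADME assay on Akata cells (Homo sapiens) for cytotoxicity (on this read-out higher numbers stand for lower toxicity in this test and lower numbers for higher toxicity in this test), compound 2 `Nc1nc2c(ncn2/C=C2\C[C@H]2[C@H](O)CO)c(=O)[nH]1` gives 86600 nM and compound 1 `Nc1nc2c(ncn2/C=C2\C[C@H]2[C@@H](O)CO)c(=O)[nH]1` gives 75000 nM, so the two stand within the scatter of each other. Compound 3 `Nc1nc2c(ncn2/C=C2/C[C@@H]2[C@H](O)CO)c(=O)[nH]1` is the next stereoisomer: the two compounds have the same atoms and bonds and differ only in configuration as drawn: 2 of 3 stereo elements differ; a stereocentre at a saturated ring carbon is drawn R in compound 2 and S in compound 3; a double bond is drawn E in compound 2 and Z in compound 3. Within the data shown here, the only measured step, a 1.2-fold higher number from compound 1 to compound 2 (0.06 log units; within the scatter), is small, but it involves a stereocentre at a saturated chain carbon, so neither the ring carbon nor the double bond has been tested. On that limited guide, no change beyond the scatter is expected, with an expected 1.1-fold lower number from compound 2 to compound 3 (0.03 log units; within the scatter). For compound 3 the estimate is 80000 nM, with an expected range of 30000 nM to 160000 nM.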

Compound 3, half-maximal cytotoxic concentration: 54000 nM
For compound 3 the middle estimate is 1.5-fold (0.17 log units) above the measured one; low and high end bracket the measured number.
By their numbers in this assay, from the lowest: compounds 3, 1 and 2 (each within the scatter of the next).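

Changing the ring stereocentre and the double bond together stays within the scatter in this assay, with a 1.6-fold lower number from compound 2 to compound 3 (0.21 log units; within the scatter). Changing all three stereo elements at once also stays within the scatter, with a 1.4-fold lower number from compound 1 to compound 3 (0.14 log units; within the scatter). The ring carbon and the double bond therefore show no joint change beyond the scatter, although their separate contributions cannot be told apart.

From the compounds shown here alone, all three compounds share the same atoms and bonds, so the effect of a change in the groups themselves remains open. Going by these compounds, whether an amine or a carboxylic acid in place of a hydroxyl group would shift the number in this assay is unknown.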